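The source may report more compounds than this note shows. Statements on the series, on what has been measured and on what is new or still open speak of the compounds shown alone.

Within the data shown here, in a physicochemical assay for lipophilicity, read by HPLC, at pH 7.5 (on this read-out higher numbers stand for higher lipophilicity and lower numbers for lower lipophilicity), compound 1, with the structure `CCOc1ccccc1-c1ccc(-c2nc3cnccc3c(N[C@H](CC(C)C)C(N)=O)c2C#N)cc1`, gives 3.4, while compound 3, `CCOc1ccccc1-c1ccc(-c2nc3cnccc3c(NC(C)C(=O)O)c2C#N)cc1`, gives 2.1; the step of a number 1.30 log units lower from compound 1 to compound 3 (beyond the scatter) is the only single-point change measured so far. Compound 2, `CC[C@@H](Nc1c(C#N)c(-c2ccc(-c3cccc(Cl)c3F)cc2)nc2cnccc12)C(N)=O`, gives 3.1, which sits within the scatter of compound 1 and above compound 3 beyond it. Compound 4, `CC[C@@H](Nc1c(C#N)c(-c2ccc(-c3cccc(Cl)c3OC)cc2)nc2cnccc12)C(N)=O`, differs from compound 2 by methoxy in place of fluoro on an aromatic carbon. Among the measured compounds shown here, the measured step from compound 1 to compound 3 concerns a different position and a different kind of group, so it does not bear on this change; no measured pair addresses the swap at hand. The change is therefore expected to move this assay little, if at all, beyond the scatter, as a number 0.10 log units lower from compound 2 to compound 4 (within the scatter). Compound 4 is estimated at 3, between 2.6 and 3.4.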

Compound 4, distribution coefficient: 3.1
Compound 4: middle estimate off by 0.10 log units, on the low side, within the range that was stated.
By their numbers in this assay, from the lowest: compound 3; then compounds 2, 4 and 1 (each within the scatter of the next).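

On the aromatic carbon ortho to a chloro group, going from 3-chloro-2-fluorophenyl to 3-chloro-2-methoxyphenyl gives, in this assay, no change at the digits printed from compound 2 to compound 4 (within the scatter). So at this position the heavy atoms rise from 1 to 2 and a hydrogen-bond acceptor enters, yet the reading holds, which the earlier compounds could not show. No measurement at hand explains this result. Going by these compounds, whether a hydroxyl or an amine on this carbon would also leave the reading in place stays open, as does whether the same swap behaves alike without the chloro group.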